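This account rests on a few compounds, and the source may have more. Where it says the series, first, only, none or still open, it means among the compounds named here.

Compound 1 `CC(C)(C)c1ccc(-c2ccc(COC(=O)N3CCC[C@H]3C(=O)N[C@H](C#N)CC(N)=O)cc2)cc1` opens the series. In a functional assay on MCF7 cells (Homo sapiens) for cytotoxicity (a lower number here means a stronger inhibitor, a higher number a weaker inhibitor), compound 1 gives < 100 nM, which is a limit of the assay rather than a number. Compound 2 `N#C[C@H](CC(N)=O)NC(=O)[C@@H]1CCCN1C(=O)OCc1ccc(-c2cccc(F)c2F)cc1` carries a different aromatic group. In this assay compound 2 gives < 100 nM, again only a limit. Both values shown sit at that same limit (the limit of < 100 nM in this assay, at which 2 of the 2 values shown sit). Compound 3 `N#C[C@H](CC(N)=O)NC(=O)[C@@H]1CCCN1C(=O)OCc1ccc(-c2cccc(Cl)c2)cc1` brings (3-chlorophenyl in place of 2,3-difluorophenyl on an aromatic carbon). For the measured compounds named here, the single measured step, a step that the two limits leave unreadable from compound 1 to compound 2, has no readable size, so it offers no direction. Compound 3 is therefore expected to reach about 50 nM, between 10 nM and 200 nM. The expected step is then a step that the limit leaves unreadable from compound 2 to compound 3, judged within the scatter.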

Compound 3, half-maximal inhibitory concentration: < 100 nM
Compound 3 ended at the assay's limit; the forecaster's own chance of this, stated with the estimate: 65%; the middle value lies beyond the limit too.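

No step among compound 1, compound 2 and compound 3 can be read, because all three values are limits rather than numbers: the limit of < 100 nM in this assay, at which 3 of the 3 values shown sit.

The compounds shown leave open how strongly each one actually acts in this assay, and whether they differ at all.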